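The source may hold more compounds than are shown below. What is called first, only, known or untested is meant among the compounds shown, and "the series" means these compounds.

In an assay on CHO cells for displacement of a labelled ligand from adenosine receptor A1 (Homo sapiens), read by scintillation counting, with a stated time of 60 min, tested at 10 uM (on this read-out higher numbers stand for more inhibition at the one concentration tested (going by the name of the read-out) and lower numbers for less inhibition), compound 1 `COc1cccc2cc(C(=O)Nc3c(C#N)ncn3-c3ccccc3)c(=N)oc12` gives 33%, and compound 2 `COc1cccc2cc(C(=O)Nc3c(C#N)ncn3-c3ccc(F)cc3)c(=N)oc12` gives 46%, the higher of the two numbers, the measured step being a number 13 percentage points higher from compound 1 to compound 2 (beyond the scatter). Compound 3 `COc1cccc2cc(C(=O)Nc3c(C#N)ncn3-c3ccc(C#N)cc3)c(=N)oc12` carries cyano in place of fluoro on an aromatic carbon. Going by the values given here, only that one step bears on this change, and it concerns fluoro entering for hydrogen, not cyano for fluoro; no measured pair shows the latter. The expectation for compound 3 is therefore a step of a number 4 percentage points higher from compound 2 to compound 3 (within the scatter) in this assay, small and not clearly beyond the scatter. Compound 3 is thus estimated at 50%, between 30% and 70%.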

Compound 3, a percentage reported as inhibition, at one concentration (the size of the read-out at that concentration, not a potency): 18%
Estimate against measurement, compound 3: 32 percentage points above, and the stated range ends above it.
By their numbers in this assay, from the lowest: compound 3; then compound 1; then compound 2.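

At this position, para to a large group, the read-out in this assay depends on which group enters, not simply on hydrogen being replaced. Cyano in place of fluoro brings a number 28 percentage points lower from compound 2 to compound 3 (beyond the scatter), and cyano in place of hydrogen brings a number 15 percentage points lower from compound 1 to compound 3 (beyond the scatter), the opposite direction to fluoro in place of hydrogen, which brought a number 13 percentage points higher from compound 1 to compound 2 (beyond the scatter). No evidence at hand explains why these two groups part ways. As far as these compounds go, whether chloro, methoxy or an amine at this position would follow fluoro or cyano remains open.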